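This account rests on a few compounds, and the source may have more. Where it says the series, first, only, none or still open, it means among the compounds named here.

Measured so far:

Compound 1, `O=C(Nc1cc(C(F)(F)F)cc(C(F)(F)F)c1)c1cc(Cl)ccc1OCc1ccccc1` — in an assay for inhibition of transmembrane protease serine 4 (Homo sapiens), read by fluorescence (on this read-out lower numbers stand for stronger inhibition and higher numbers for weaker inhibition), compound 1 gives only a limit, > 100000 nM.
Compound 2, `O=C(Nc1cc(C(F)(F)F)ccc1C(F)(F)F)c1cc(Cl)ccc1O` — in this assay compound 2 gives 20000 nM.
Compound 3, `COc1c(C(F)(F)F)cc(NC(=O)c2cc(Cl)ccc2O)cc1C(F)(F)F` — in this assay compound 3 gives 12000 nM.

The three compounds share the same core and differ only in the substituents around it. Compound 1 stands apart in that it gives no number at all, only (the limit of > 100000 nM in this assay, at which 1 of the 3 values shown sits). Compound 2 and compound 3 both give numbers, and these two numbers lie within the usual scatter of each other, so neither can be called stronger or weaker than the other on this evidence.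

The next compound, compound 4, `Cc1c(C(F)(F)F)cc(NC(=O)c2cc(Cl)ccc2O)cc1C(F)(F)F`, is made from compound 3 by a single small change: methyl in place of methoxy on an aromatic carbon. Among the compounds with values here, no pair of measured compounds shows this kind of exchange, so there is nothing to calibrate the step against. The exchange is small in size, and the expectation is a step in this assay that stays within the scatter, with no clear direction. Compound 4 is therefore expected to give about 15000 nM, in a range from 5000 nM to 50000 nM, which corresponds to an expected step of a 1.3-fold higher number from compound 3 to compound 4 (0.10 log units; within the scatter).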

Compound 4, half-maximal inhibitory concentration: 10000 nM
The estimate for compound 4 lay 1.5-fold (0.18 log units) above the measured number; the range from low to high includes it.
By their numbers in this assay, from the lowest: compounds 4, 3 and 2 (each within the scatter of the next). At a limit, above all of these: compound 1.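

This is the first pair shown that differs in only one place, so the exchange of methoxy for methyl, on the aromatic carbon ortho to two trifluoromethyl groups, can now be read directly in this assay: a 1.2-fold lower number from compound 3 to compound 4 (0.08 log units; within the scatter). The methoxy group carries a hydrogen-bond acceptor and the methyl group carries none, yet the two numbers cannot be told apart, so on this one pair the acceptor makes no readable difference at this position. Nothing measured here offers a reason for this result.

Going by these compounds, what an amine, a carboxylic acid or a longer chain such as propoxy would do at this position stays open. Within the data shown here, whether the same exchange would behave alike with other substituents on the shared core also stays open, as this is the only pair of its kind.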